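This account rests on a few compounds, and the source may have more. Where it says the series, first, only, none or still open, it means among the compounds named here.

Measured so far:
compound 1 `CN1CCN(c2nc(-c3cccc(Cl)c3)nc3c2ncn3C)CC1` – 38.3%
compound 2 `Clc1cccc(-c2nc(N3CCCCC3)c3nc[nH]c3n2)c1` – > 80%

In an assay on cells for displacement of a labelled ligand from adenosine receptor A3 (Homo sapiens), read by scintillation counting and radioligand binding, with a stated time of 180 min, tested at 10 uM (a higher number here means more inhibition at the concentration tested (going by the name of the read-out), a lower number less inhibition), compound 1 gives 38.3%. For compound 2 the assay reports only a limit, > 80%, not a number (the limit of > 80% in this assay, at which 1 of the 2 values shown sits). Compound 3 `Cn1cnc2c(N3CCCCC3)nc(-c3cccc(Cl)c3)nc21` differs from compound 2 by methyl in place of hydrogen on an aromatic nitrogen. Among the measured compounds shown here, no measured pair shows this change on its own; compound 1 also carries such a methyl but differs elsewhere too, so its value alone cannot settle the step. A fall in this assay of moderate size, beyond the usual scatter, is expected, a number at least 20 percentage points lower from compound 2 to compound 3 (beyond the scatter). Compound 3 is estimated at 60%, with a range from 30% to 88%.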

Compound 3, a percentage reported as inhibition, at one concentration (the size of the read-out at that concentration, not a potency): 6.1%
For compound 3 the middle estimate is 53.9 percentage points above the measured one; the whole stated range lies above it.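

In this assay compound 2 holds a limit of the assay, not a number: the limit of > 80% in this assay, at which 1 of the 3 values shown sits.

Even so, methyl in place of hydrogen on an aromatic nitrogen gives a number at least 73.9 percentage points lower from compound 2 to compound 3 (beyond the scatter), the first reading of this single change, and it removes most of the inhibition. With that methyl present in both, piperidin-1-yl in place of 4-methylpiperazin-1-yl on an aromatic carbon gives a number 32.2 percentage points lower from compound 1 to compound 3 (beyond the scatter), so the group at that second place also counts.

The compounds shown leave open what ethyl or a longer chain on that nitrogen would give. They also leave open how 4-methylpiperazin-1-yl behaves when the nitrogen carries hydrogen.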